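Swapping Fluoro for Methoxy: Expected Cytotoxicity of Compound 4

The source may report more compounds than this note shows. Statements on the series, on what has been measured and on what is new or still open speak of the compounds shown alone.

Compound 1 `O=[N+]([O-])c1cn2c(n1)OC[C@@H](OCc1ccc(-c3ccc(OC(F)(F)F)cc3)cc1F)C2` was tested in an ADME assay on Vero cells (Chlorocebus sabaeus) for cytotoxicity, with a stated time of 72 h; a higher number here means a weaker inhibitor, a lower number a stronger inhibitor. In this assay compound 1 gives only a limit, > 128000 nM. Compound 2 `O=[N+]([O-])c1cn2c(n1)OC[C@@H](OCc1ccc(-c3ccc(OC(F)(F)F)cc3)c(F)c1)C2` likewise gives only a limit in this assay, > 128000 nM. Compound 3 `O=[N+]([O-])c1cn2c(n1)OC[C@@H](OCc1c(F)cc(-c3ccc(OC(F)(F)F)cc3)cc1F)C2` also gives only a limit in this assay, > 128000 nM. The step that the two limits leave unreadable from compound 1 to compound 3 cannot be sized because the limit of > 128000 nM in this assay, at which 3 of the 3 values shown sit, hides any difference. Compound 4 `COc1cc(-c2ccc(OC(F)(F)F)cc2)ccc1CO[C@@H]1COc2nc([N+](=O)[O-])cn2C1` differs from compound 1 by methoxy in place of fluoro on an aromatic carbon. Going by the values given here, no measured step bears directly on this exchange; all that is known is that every value so far sits at the limit. Compound 4 is therefore expected to remain weak in this assay as well, at an estimated 150000 nM with a range from 60000 nM to 400000 nM, a step that the limit leaves unreadable from compound 1 to compound 4 that is expected to stay within the scatter.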

Compound 4, half-maximal inhibitory concentration: > 128000 nM
Compound 4: a limit, no number (the forecaster's own chance of this, stated with the estimate: 80%); the middle value is on the limit's open side.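

No size can be given for the change from compound 1 to compound 4, because both give only a limit: the limit of > 128000 nM in this assay, at which 4 of the 4 values shown sit. The compounds shown leave open whether methoxy in place of fluoro changes anything in this assay.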